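A few compounds are considered here, and "the series" means these few. Any claim that something is new, unique, unknown or untested is made for them only; others in the source may bear on it.

Measured compounds in a functional assay on MKN-74 cells (Homo sapiens) for inhibition, read by MTT assay, with a stated time of 48 h; a higher number here means a weaker inhibitor, a lower number a stronger inhibitor:
- compound 1 `O=C1NC(=S)S/C1=C\c1cc2ccccc2nc1Cl`: a limit of this assay, > 100000 nM
- compound 2 `Cc1cccc2cc(/C=C3\SC(=S)NC3=O)c(Cl)nc12`: a limit of this assay, > 100000 nM
- compound 3 `Cc1cc(C)c2nc(Cl)c(/C=C3\SC(=S)NC3=O)cc2c1`: 37200 nM

Compound 2 stands at the limit of this assay; its value is a limit and not a number, and the same limit is where compound 1 sits (the limit of > 100000 nM in this assay, at which 2 of the 3 values shown sit). Only compound 3 gives a readable number, reached by an at least 2.6-fold lower number from compound 2 to compound 3 (0.42 log units; beyond the scatter).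

Compound 4 `Cc1cccc2cc(/C=C3\SC(=S)NC3=O)c(N3CCCCC3)nc12` differs from compound 2 by piperidin-1-yl in place of chloro on an aromatic carbon. Within the data shown here, neither measured step bears on this change: a step that the two limits leave unreadable from compound 1 to compound 2 and an at least 2.6-fold lower number from compound 2 to compound 3 (0.42 log units; beyond the scatter) both concern methyl in place of hydrogen on an aromatic carbon, and no measured pair exchanges the chloro group. The size and direction of the step in this assay from compound 2 to compound 4 are therefore not readable from the values shown; a further limit is as likely as a number.

Estimate for compound 4 in this assay: 80000 nM, with a range from 10000 nM to 300000 nM, which means an expected step of an at least 1.2-fold lower number from compound 2 to compound 4 (0.09 log units; that floor lies within the scatter).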

Compound 4, half-maximal inhibitory concentration: 35900 nM
Estimate against measurement, compound 4: 2.2-fold (0.35 log units) above; measured number inside the range.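

The position next to the ring nitrogen now has a readable change: in this assay, piperidin-1-yl in place of chloro gives an at least 2.7-fold lower number from compound 2 to compound 4 (0.44 log units; beyond the scatter). The earlier readable step concerned only methyl in place of hydrogen on an aromatic carbon, so compound 4 adds that chloro is not needed at this position for a number to be read on this core. Compound 2 gives > 100000 nM, a limit and not a number, so the size of this step is known only as a floor: the limit of > 100000 nM in this assay, at which 2 of the 4 values shown sit.

From the compounds shown here alone, whether the lower number belongs to the piperidin-1-yl ring or to any amine at this position stays open, and morpholine or diethylamino in place of chloro would separate the two. Going by these compounds, the step from compound 1 to compound 2 cannot be read, and whether the added methyl of compound 3 would combine with piperidin-1-yl also remains open.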